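Diaryl urea inhibitors of KETR3 cell growth: a positional isomer

The source may hold more compounds than are shown below. What is called first, only, known or untested is meant among the compounds shown, and "the series" means these compounds.

The study measures inhibition of cell growth in a functional assay on KETR3 cells (Homo sapiens) for inhibition, read by MTT assay, with a stated time of 120 h; a higher number here means a weaker inhibitor, a lower number a stronger inhibitor. Two compounds have numbers. Compound 1 `CNC(=O)/C(C)=C/c1ccc(NC(=O)Nc2ccc(Cl)c(C(F)(F)F)c2)cc1` returns only a limit of the assay in this assay, > 50000 nM, so no number is known for it; it sits at the limit of > 50000 nM in this assay, at which 1 of the 2 values shown sits. Compound 2 `CC(NC(=O)c1ccc(-c2ccc(NC(=O)Nc3cc(C(F)(F)F)ccc3Cl)cc2)cc1)c1ccccc1` gives 16800 nM in this assay, the only number shown.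

Compound 3 `CC(NC(=O)c1ccc(-c2ccc(NC(=O)Nc3ccc(Cl)c(C(F)(F)F)c3)cc2)cc1)c1ccccc1` has not yet been measured. It differs from compound 2 only in how the same atoms are joined: 4-chloro-3-(trifluoromethyl)phenyl in place of 2-chloro-5-(trifluoromethyl)phenyl on an amide-type nitrogen. Among the compounds with values here, since no pair of measured compounds shows the effect of this change, the expected step from compound 2 to compound 3 rests on compound 2 alone and on its being a rearrangement of the same groups; a step of a 1.3-fold higher number from compound 2 to compound 3 (0.12 log units; within the scatter) is expected, toward a weaker inhibitor. Compound 3 is therefore estimated at 22000 nM, within 7000 nM to 60000 nM.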

Compound 3, half-maximal inhibitory concentration: 19300 nM
Estimate against measurement, compound 3: 1.1-fold (0.06 log units) above; the measured number falls inside the stated range.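

In this assay, 4-chloro-3-(trifluoromethyl)phenyl in place of 2-chloro-5-(trifluoromethyl)phenyl on an amide-type nitrogen gives a 1.1-fold higher number from compound 2 to compound 3 (0.06 log units; within the scatter), so the two isomers cannot be told apart. Within the data shown here, this is the first pair that differs in one place, and it shows that, between these two arrangements of chlorine and trifluoromethyl, the assay does not separate the compounds. Nothing shown bears on why the two isomers read alike.

From the compounds shown here alone, whether a carboxylic acid or an amine in place of the chlorine or the trifluoromethyl would give a number clearly apart from these two remains open. Compound 1 has only a limit and differs from compound 3 in more than one place, so it cannot be set against this pair.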